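Aryl sulfonamide variation on a shared core

The source may hold more compounds than are shown below. What is called first, only, known or untested is meant among the compounds shown, and "the series" means these compounds.

The three measured compounds share one core and differ only in the aryl group on the sulfonyl sulfur. In an assay on brain for displacement of a labelled ligand from 5-hydroxytryptamine receptor 4 (Cavia porcellus), with a stated time of 30 min, in the presence of a further agent that is not named here (a higher number here means a weaker inhibitor, a lower number a stronger inhibitor), compound 1 `COc1cc(N)c(Cl)cc1C(=O)CCC1CCN(CCNS(=O)(=O)c2cc(Br)ccc2Br)CC1` gives 16.3 nM. Compound 2 `COc1ccc(S(=O)(=O)NCCN2CCC(CCC(=O)c3cc(Cl)c(N)cc3OC)CC2)cc1Cl` gives 22.5 nM in this assay, the highest of the three numbers, though the step of a 1.4-fold higher number from compound 1 to compound 2 (0.14 log units; within the scatter) lies within the scatter, so compound 1 and compound 2 cannot be ordered. Compound 3 `COc1cc(N)c(Cl)cc1C(=O)CCC1CCN(CCNS(=O)(=O)c2ccc(N)cc2)CC1` gives 1.97 nM in this assay, the lowest number; the steps of an 8.3-fold lower number from compound 1 to compound 3 (0.92 log units; beyond the scatter) and an 11-fold lower number from compound 2 to compound 3 (1.06 log units; beyond the scatter) both lie beyond the scatter.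

Compound 4 `COc1cc(N)c(Cl)cc1C(=O)CCC1CCN(CCNS(=O)(=O)c2cc(Br)c(N)c(Br)c2)CC1` is not yet measured in this assay. It differs from compound 2 by 4-amino-3,5-dibromophenyl in place of 3-chloro-4-methoxyphenyl on a sulfonyl sulfur. Going by the values given here, two measured steps bear on this. The step of an 11-fold lower number from compound 2 to compound 3 (1.06 log units; beyond the scatter) shows what the 4-aminophenyl alone does against the same starting point. The step of a 1.4-fold higher number from compound 1 to compound 2 (0.14 log units; within the scatter) shows that exchanging one halogenated aryl group for another stays within the scatter. Among the compounds with values here, compound 4 combines the amino group of compound 3 with two bromines; no measured pair shows that combination. A step in the same direction as an 11-fold lower number from compound 2 to compound 3 (1.06 log units; beyond the scatter) but of smaller size is expected, about a 4.5-fold lower number from compound 2 to compound 4 (0.65 log units; beyond the scatter). Compound 4 is therefore estimated at 5 nM in this assay, with a range from 1.5 nM to 15 nM.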

Compound 4, inhibition constant: 8.7 nM
Compound 4: middle estimate off by 1.7-fold (0.24 log units), on the low side; the range from low to high includes it.
By their numbers in this assay, from the lowest: compound 3; then compounds 4, 1 and 2 (each within the scatter of the next, the first and the last beyond it).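

Placing the two bromines on the 4-aminophenyl group costs binding in this assay, with a 4.4-fold higher number from compound 3 to compound 4 (0.65 log units; beyond the scatter), so the amino group does not keep the low number of compound 3 whatever else the ring carries. The 4-amino-3,5-dibromophenyl group still retains part of the advantage over 3-chloro-4-methoxyphenyl, as a 2.6-fold lower number from compound 2 to compound 4 (0.41 log units; beyond the scatter) lies beyond the scatter, yet a 1.9-fold lower number from compound 1 to compound 4 (0.27 log units; within the scatter) lies within it, so compound 1, which has no amino group, cannot be ordered against compound 4 and the amino group alone does not separate the aryl groups at this position. No measurement on hand accounts for any of these steps.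

The compounds shown leave open whether a single bromine on the 4-aminophenyl group would give a number nearer to that of compound 3 or of compound 4, and whether chlorine or methyl in place of the bromines would give the same step. They also leave open whether a hydroxyl group, an acetamide or a dimethylamino group could stand in for the amino group on the ring without the number rising.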